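The source may report more compounds than this note shows. Statements on the series, on what has been measured and on what is new or still open speak of the compounds shown alone.

Compound 1 `Clc1ccc(Cn2cncc2CNc2cccc(-c3ccccc3)c2)cc1`: in a toxicity assay on NIH3T3 cells (Mus musculus) for cytotoxicity, read by resazurin assay (a lower number here means that less compound is needed, a higher number that more compound is needed for the effect), compound 1 gives 10000 nM.
Compound 2 `COC(=O)c1ccc(NCc2cncn2Cc2ccc(Cl)cc2)cc1-c1ccccc1`: in this assay compound 2 gives 25000 nM.
Compound 3 `Clc1ccc(Cn2cncc2CNc2ccc(-c3nc4ccccc4s3)c(-c3ccccc3)c2)cc1`: in this assay compound 3 gives only a limit, > 1000 nM.

Compound 2 holds the highest of the two readable numbers; the step of a 2.5-fold higher number from compound 1 to compound 2 (0.40 log units; beyond the scatter) separates it from compound 1. Because compound 3 sits at the limit of > 1000 nM in this assay, at which 1 of the 3 values shown sits, the steps a step that the limit leaves unreadable from compound 1 to compound 3 and a step that the limit leaves unreadable from compound 2 to compound 3 cannot be sized. Compound 4 `COC(=O)c1ccc(NCc2cncn2Cc2ccccc2)cc1-c1ccccc1` differs from compound 2 by hydrogen in place of chloro on an aromatic carbon. Among the compounds with values here, no measured step touches that position: the only readable step, a 2.5-fold higher number from compound 1 to compound 2 (0.40 log units; beyond the scatter), concerns another group. The expected step of no change at the digits printed from compound 2 to compound 4 (within the scatter) is therefore estimated to stay within the scatter. Compound 4 is expected to give 25000 nM, with a range from 10000 nM to 60000 nM.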

Compound 4, half-maximal effective concentration: > 1000 nM
Compound 4: only a limit was reported; the forecaster's own chance of this, stated with the estimate: 15%; the middle value is on the limit's open side.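

In this assay compound 4 gives only a limit, so no new step can be read between compound 2 and compound 4. The compounds shown leave open whether hydrogen in place of chloro changes the number at all.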